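A few compounds are considered here, and "the series" means these few. Any claim that something is new, unique, unknown or untested is made for them only; others in the source may bear on it.

Among the measured compounds shown here, in a physicochemical assay for lipophilicity, using the shake flask method, in phosphate buffer, measured as octanol-water partition, with a stated time of 30 min, at pH 7.4 (on this read-out higher numbers stand for higher lipophilicity and lower numbers for lower lipophilicity), two compounds sharing one core have numbers so far. Compound 1 `O=C(Nc1ccccc1)c1cnc(NCc2c(F)ccc3c2CCO3)n2cnnc12` gives 4.1, and compound 2 `O=C1CC2(CC2)CN1c1cnc(NCc2c(F)ccc3c2CCO3)n2cnnc12` gives 1.9, the lower of the two. Compound 3 `O=C1CCCN1c1cnc(NCc2c(F)ccc3c2CCO3)n2cnnc12` keeps the shared core and differs from compound 2 in one group on an aromatic carbon: a group of 6 heavy atoms (4 carbon, 1 nitrogen, 1 oxygen; one five-membered non-aromatic ring with 1 hetero atom) in place of a group of 8 heavy atoms (6 carbon, 1 nitrogen, 1 oxygen; one three-membered non-aromatic ring of carbon only, one five-membered non-aromatic ring with 1 hetero atom), on an aromatic carbon. The entering group is 2-oxopyrrolidin-1-yl, so the five-membered ring with its carbonyl stays and the three-membered ring of carbon only goes.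

Just one measured step bears on this change: a number 2.20 log units lower from compound 1 to compound 2 (beyond the scatter). For the measured compounds named here, it is only a loose guide, since it removed a six-membered aromatic ring of carbon only, and no measured step removes a three-membered ring alone. A much smaller step than that one is therefore expected in this assay, towards lower numbers, starting from compound 2 at 1.9. The expected step is a number 0.50 log units lower from compound 2 to compound 3 (beyond the scatter). Compound 3 is estimated at 1.4, with an expected range from 1 to 1.8.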

Compound 3, distribution coefficient: 1.3
The estimate for compound 3 lay 0.10 log units above the measured number, and the stated range covers the measured number.
By their numbers in this assay, from the lowest: compound 3; then compound 2; then compound 1.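

In this assay, going from the group with the three-membered ring of carbon only to 2-oxopyrrolidin-1-yl gives a number 0.60 log units lower from compound 2 to compound 3 (beyond the scatter) on the same aromatic carbon, so this position responds beyond the scatter even when the five-membered ring and its carbonyl stay and both groups have the same printed counts of hydrogen-bond donors and acceptors. Measured against the phenylcarbamoyl group of compound 1, 2-oxopyrrolidin-1-yl gives a number 2.80 log units lower from compound 1 to compound 3 (beyond the scatter) and places compound 3 lowest of the three, so among these compounds the two groups with a five-membered ring and a carbonyl both stand well under the phenylcarbamoyl compound, and they also differ from each other. Nothing at hand gives a reason for either step.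

The compounds shown leave open how the number would move at this position with a four-membered ring carrying the carbonyl, an open-chain amide, an amine or a carboxylic acid in place of 2-oxopyrrolidin-1-yl. From the compounds shown here alone, all three compounds also share one core, so whether these steps would hold on any other core remains unknown.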